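Swapping Selenium for Sulfur on a Shared Core

The source may report more compounds than this note shows. Statements on the series, on what has been measured and on what is new or still open speak of the compounds shown alone.

Compound 3 `CSc1ccc(CNc2nc([Se]C)nc3ccccc23)cc1` carries a methyl on a selenium attached to the shared core. In a functional assay on MCF7 cells (Homo sapiens) for cytotoxicity, read by MTT assay, with a stated time of 72 h (a lower number here means that less compound is tolerated, a higher number that more compound is tolerated), compound 3 gives > 100000 nM, which is a limit of the assay rather than a number. Compound 1 `CSc1ccc(CNc2nc([SeH])nc3ccccc23)cc1` bears hydrogen on that selenium, and in this assay compound 1 gives > 100000 nM, again a limit. Compound 2 `CCCCC[Se]c1nc(NCc2ccc(SC)cc2)c2ccccc2n1` carries a pentyl on the selenium, and in this assay compound 2 gives 95300 nM. The step that the two limits leave unreadable from compound 1 to compound 3 cannot be read, while an at least 1.0-fold higher number from compound 2 to compound 3 (0.02 log units; that floor lies within the scatter) lies within the scatter; the limit of > 100000 nM in this assay, at which 2 of the 3 values shown sit, marks where compound 3 stands. Compound 4 `CSc1ccc(CNc2nc(SC)nc3ccccc23)cc1` differs from compound 3 by a group of 2 heavy atoms (1 carbon, 1 sulfur; no ring) in place of a group of 2 heavy atoms (1 carbon, 1 selenium; no ring), on an aromatic carbon. Going by the values given here, none of the measured steps exchanges selenium for sulfur; they only change what sits on the selenium, and of these the one that can be read stays within the scatter while the other cannot be read. Compound 4 is therefore expected to sit near the same limit, with an expected step that the limit leaves unreadable from compound 3 to compound 4. The estimate for compound 4 in this assay is 110000 nM, with a range from 50000 nM to 300000 nM.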

Compound 4, concentration lethal to 50% of the cells: > 100000 nM
Compound 4 gave a limit, no number; the forecaster's own chance of this, stated with the estimate: 70%; the middle value does not contradict the limit.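

Going by these compounds alone, compound 4 carries methylsulfanyl on the aromatic carbon between two ring nitrogen atoms, the carbon that bears selenium in the earlier compounds, and in this assay compound 4 gives > 100000 nM, which is a limit of the assay. Within the data shown here, the steps to compound 4 from compound 1 and from compound 3 cannot be read, as both ends of each are limits, so the exchange of selenium for sulfur gains no measurable size, while the one step that can be read is an at least 1.0-fold higher number from compound 2 to compound 4 (0.02 log units; that floor lies within the scatter). What this position newly shows is only that a sulfur-linked group here also leaves the result at the limit, and not just the selenium-linked hydrogen and methyl: the limit of > 100000 nM in this assay, at which 3 of the 4 values shown sit.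

Among these compounds, a sulfur-bound pentyl would allow a direct comparison with compound 2, the only compound here with a number, and what it would give stays open. Also open, as far as these compounds go, is whether an amine or a carboxylic acid on that aromatic carbon would bring a value in this assay clearly beyond the scatter of the values shown.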